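Working notes: enlarging the sulfur chain of compound 2

A few compounds are considered here, and "the series" means these few. Any claim that something is new, unique, unknown or untested is made for them only; others in the source may bear on it.

Compound 1 (`COc1ccc(-n2c(SC)nnc2-c2cc(OC)c(OC)c(OC)c2)cc1`) gives > 60000 nM in a functional assay on HT-29 cells (Homo sapiens) for inhibition, read by MTT assay, with a stated time of 48 h (on this read-out lower numbers stand for stronger inhibition and higher numbers for weaker inhibition), and this is a limit, not a number. Compound 2 (`CCSc1nnc(-c2cc(OC)c(OC)c(OC)c2)n1-c1ccc(N(C)C)cc1`) gives > 60000 nM in this assay and this too is a limit, not a number. For the measured compounds named here, the position of compound 2 is therefore known only as a limit, and the series so far comes down to the limit of > 60000 nM in this assay, at which 2 of the 2 values shown sit, with no number to work from.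

Compound 3 (`COc1cc(-c2nnc(SCC(=O)c3ccc(F)cc3)n2-c2ccc(N(C)C)cc2)cc(OC)c1OC`) carries (4-fluorophenyl)carbonyl in place of methyl on a saturated chain carbon bound to a sulfur, counted as (4-fluorophenyl)carbonyl in place of methyl on a saturated chain carbon bound to a sulfur with the rest of compound 2 unchanged. Read one bond further out, ethylsulfanyl becomes (((4-fluorophenyl)carbonyl)methyl)sulfanyl.

Going by the values given here, no measured step exists, so the size of the change can only be loosely estimated. The expected step of an at least 7.5-fold lower number from compound 2 to compound 3 (0.87 log units; beyond the scatter) runs towards stronger inhibition in this assay and a reading again at the limit stays possible. The expected value for compound 3 is 8000 nM within an estimated range from 400 nM to 60000 nM in this read-out.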

Compound 3, half-maximal inhibitory concentration: 78100 nM
Compound 3: middle estimate off by 9.8-fold (0.99 log units), on the low side; measured number outside the range, above it.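

No step can be read from compound 2 to compound 3, because the reading for compound 2 is a limit and not a number: the limit of > 60000 nM in this assay, at which 2 of the 3 values shown sit.

The compounds shown leave open whether (4-fluorophenyl)carbonyl in place of methyl on a saturated chain carbon bound to a sulfur changes inhibition at all in this assay.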